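A few compounds are considered here, and "the series" means these few. Any claim that something is new, unique, unknown or untested is made for them only; others in the source may bear on it.

Compound 1 `CCCCC#Cc1cc(C(=O)OCC)nc2ccc(OC)cc12` is the reference here. In a functional assay on Jurkat cells (Homo sapiens) for cytotoxicity, read by MTT assay, with a stated time of 24 h (a lower number here means that less compound is needed, a higher number that more compound is needed for the effect), compound 1 gives 15900 nM, the lowest of the three numbers at hand. Compound 3 `COc1ccc2nc(-c3c(C)cccc3C)cc([Se]c3ccccc3)c2c1`, which gives 26900 nM, sits within the scatter of compound 1, so the two cannot be told apart. Among the measured compounds shown here, compound 2 `CCOC(=O)c1cc(C#Cc2ccc(N)cc2)c2cc(OC)ccc2n1` gives 61000 nM, and the one measured step, a 3.8-fold higher number from compound 1 to compound 2 (0.58 log units; beyond the scatter), came from putting 4-aminophenyl in place of butyl on a triple-bonded carbon. Compound 4 `CCOC(=O)c1cc([Se]c2ccc(F)cc2)c2cc(OC)ccc2n1` changes compound 1 differently: a group of 8 heavy atoms (6 carbon, 1 fluorine, 1 selenium; one six-membered aromatic ring of carbon only) in place of a group of 6 heavy atoms (6 carbon; no ring), on an aromatic carbon, on the carbon meta to the ethoxycarbonyl group. For the measured compounds named here, no measured step matches this change; compound 3 carries a selenium-linked ring at that position, but differs from compound 1 elsewhere too, so only its value can be consulted. The expectation is therefore a small rise at most, within or near the scatter, and compound 4 is estimated at 23000 nM (range 8000 nM to 65000 nM), a step of a 1.4-fold higher number from compound 1 to compound 4 (0.16 log units; within the scatter) expected from compound 1.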

Compound 4, half-maximal effective concentration: 134000 nM
Beside the measured number, compound 4's estimate is 5.8-fold (0.77 log units) below it; the whole stated range lies below it.
By their numbers in this assay, from the lowest: compounds 1 and 3 (each within the scatter of the next); then compound 2; then compound 4.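

In this assay, the selenium-bearing group in place of hex-1-yn-1-yl gives an 8.4-fold higher number from compound 1 to compound 4 (0.93 log units; beyond the scatter), so this position is not indifferent to the exchange. With a 3.8-fold higher number from compound 1 to compound 2 (0.58 log units; beyond the scatter), there are now two replacements on the core of compound 1, both carrying an aromatic ring, and both raise the number. Nothing measured here accounts for the rise. The compounds shown leave open whether the selenium link or the fluorine matters more, since no unsubstituted phenyl on selenium appears. On these data alone, how a simple alkyl chain on selenium would read also remains open.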